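The compounds below may be only part of what the source reports. "The series", "measured", "known", "first", "only" and "open" are said of these compounds alone.

Measured so far:
compound 1 `CCCCCCCCOc1ccc2c(Cl)ccnc2c1` — 3640 nM
compound 2 `CN(C)CCNc1ccnc2cc(OCc3ccccc3)ccc12` — 2350 nM
compound 3 `CCCCCCOc1ccc2c(Cl)ccnc2c1` — 2720 nM

In a functional assay on RKO cells (Homo sapiens) for cytotoxicity, read by MTT assay, with a stated time of 48 h (on this read-out lower numbers stand for stronger inhibition and higher numbers for weaker inhibition), compound 3 stands second highest of the three numbers, within the scatter of both compound 1 and compound 2. Compound 4 `CCOc1ccc2c(Cl)ccnc2c1` differs from compound 3 by hydrogen in place of butyl on a saturated chain carbon, two bonds along the chain from an oxygen on an aromatic ring. Among the measured compounds shown here, the one measured step that bears on this, shortening the same chain, is a 1.3-fold lower number from compound 1 to compound 3 (0.13 log units; within the scatter), which stayed within the scatter. Nothing else measured here touches this chain. A further shortening is therefore expected to give no step beyond the scatter, with no direction to call. The estimated step is a 1.1-fold higher number from compound 3 to compound 4 (0.04 log units; within the scatter). For compound 4 the expected value in this assay is 3000 nM, within a range from 1200 nM to 8000 nM.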

Compound 4, half-maximal inhibitory concentration: 3870 nM
Compound 4: the middle estimate sits 1.3-fold (0.11 log units) below what was measured, and the stated range covers the measured number.
By their numbers in this assay, from the lowest: compounds 2, 3, 1 and 4 (each within the scatter of the next).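

In this assay, hydrogen in place of butyl gives a 1.4-fold higher number from compound 3 to compound 4 (0.15 log units; within the scatter) and hydrogen in place of hexyl gives a 1.1-fold higher number from compound 1 to compound 4 (0.03 log units; within the scatter), so both steps at this chain carbon stay within the scatter. Even the largest cut to the chain shown here moves the number by no more than the scatter, and compounds 1, 3 and 4 cannot be put in order. Nothing measured here explains this result.

On these data alone, it remains open whether an amine or a carboxylic acid on this chain would give a step beyond the scatter. The same question stands for a chain longer than that of compound 1.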